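This account rests on a few compounds, and the source may have more. Where it says the series, first, only, none or still open, it means among the compounds named here.

Values so far in a functional assay on a cell-free system (plasma, Homo sapiens) for inhibition, with Plasma (Rattus norvegicus) as the target (a lower number here means a stronger inhibitor, a higher number a weaker inhibitor), for the series:
- compound 1 `Cc1c(OCc2ccccc2)ccc2c(N3CCNCC3)cc(=O)oc12` gives 1900 nM
- compound 2 `COc1c(C)cnc(COc2ccc3c(N4CCNCC4)cc(=O)oc3c2C)c1C` gives 3300 nM
- compound 3 `CSCOc1ccc2c(N3CCNCC3)cc(=O)oc2c1C` is not yet measured

Going by the values given here, compound 2 gives 3300 nM and so stands within the scatter of compound 1 at 1900 nM on the only two numbers available. The next change leads to compound 3 and is described by methylsulfanyl in place of 4-methoxy-3,5-dimethylpyridin-2-yl on a saturated chain carbon bound to an oxygen on an aromatic ring. Among the compounds with values here, one measured step bears on this place: the exchange of phenyl for 4-methoxy-3,5-dimethylpyridin-2-yl gave a 1.7-fold higher number from compound 1 to compound 2 (0.24 log units; within the scatter) and stayed within the scatter. Within the data shown here, no measured compound carries a group without a ring at this place, so that single step is a loose guide and the range is kept wide. The estimated move is a 1.1-fold lower number from compound 2 to compound 3 (0.04 log units; within the scatter) and no step beyond the scatter is expected in either direction. In this assay compound 3 is estimated at 3000 nM with an expected range from 1000 nM to 9000 nM as the working figure.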

Compound 3, half-maximal inhibitory concentration: 900 nM
For compound 3 the middle estimate is 3.3-fold (0.52 log units) above the measured one, and the stated range ends above it.
By their numbers in this assay, from the lowest: compound 3; then compounds 1 and 2 (each within the scatter of the next).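

In this assay, going by these compounds alone, methylsulfanyl on a saturated chain carbon bound to an oxygen on an aromatic ring gives the first steps beyond the scatter: a 3.7-fold lower number from compound 2 to compound 3 (0.56 log units; beyond the scatter), and a 2.1-fold lower number from compound 1 to compound 3 (0.32 log units; beyond the scatter). The exchange of phenyl for 4-methoxy-3,5-dimethylpyridin-2-yl had left open whether the group at this place matters at all; with compound 3 as the strongest inhibitor of the three, the number does respond to this place, though both steps are modest in size. The data offer nothing that accounts for the difference.

The compounds shown leave open whether the lower number goes with the sulfur, with the absence of a ring or with the smaller group, as methylsulfanyl differs from both phenyl and 4-methoxy-3,5-dimethylpyridin-2-yl in all three at once. A methoxy group would bear on the sulfur, a longer chain such as ethylsulfanyl on size, and an amine or a carboxylic acid at this place remains an open question too.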